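The source may report more compounds than this note shows. Statements on the series, on what has been measured and on what is new or still open speak of the compounds shown alone.

Measured in a functional assay on HepG2 cells (Homo sapiens) for cytotoxicity, read by MTT assay, with a stated time of 48 h; a lower number here means a stronger inhibitor, a higher number a weaker inhibitor:
- compound 1 `COc1cc(/C=C/C(=O)/C=C/c2nc3cc(C)ccc3n2C)ccc1O`: 4200 nM
- compound 2 `COc1cc(/C=C/C(=O)/C=C/c2nc3c(C)cccc3n2C)ccc1O`: 1900 nM

Compound 2, at 1900 nM, holds the lower of the two numbers in this assay, and its gap to compound 1 lies beyond the scatter. Compound 3 `COc1cc(/C=C/C(=O)/C=C/c2nc3c(C)c(C)ccc3n2C)ccc1O` is not yet measured. It differs from compound 2 as follows: methyl in place of hydrogen on an aromatic carbon, ortho to a methyl group. Within the data shown here, no step between measured compounds that differ in one place is available to guide the expectation. The only spread on hand is that between compound 1 at 4200 nM and compound 2 at 1900 nM, which is modest. A small change in this assay, not beyond the scatter, is therefore expected. The expected change is a 1.1-fold lower number from compound 2 to compound 3 (0.05 log units; within the scatter). For compound 3 the estimated value is 1700 nM, with an expected range of 750 nM to 4000 nM.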

Compound 3, half-maximal inhibitory concentration: 8500 nM
Beside the measured number, compound 3's estimate is 5.0-fold (0.70 log units) below it; the whole stated range lies below it.
By their numbers in this assay, from the lowest: compound 2; then compound 1; then compound 3.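

In this assay, the methyl group in place of hydrogen on this aromatic carbon, ortho to a methyl group, does not leave the number unchanged: the result is a 4.5-fold higher number from compound 2 to compound 3 (0.65 log units; beyond the scatter). The same addition read from the other single-methyl compound gives a 2.0-fold higher number from compound 1 to compound 3 (0.31 log units; beyond the scatter), so among these three compounds the two methyl groups together give a higher number than either one alone, a combination the earlier pair could not address. No data available here explain this rise.

As far as these compounds go, whether the rise is specific to methyl at this carbon remains open, as a fluorine, a methoxy group or an amine there could give a different number. Also open, from the compounds shown here alone, is whether the second methyl would have the same effect on the shared core with other substituents elsewhere, such as a longer alkyl chain in place of the existing methyl group.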